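The source may report more compounds than this note shows. Statements on the series, on what has been measured and on what is new or still open speak of the compounds shown alone.

Of the compounds shown here, three have so far been measured in an assay on HEK293 cells for displacement of a labelled ligand from metabotropic glutamate receptor 5 (Homo sapiens), with a stated time of 2 h; on this read-out lower numbers stand for stronger inhibition and higher numbers for weaker inhibition. Compound 1 `CN1CCc2nc(C#Cc3ccccn3)ccc2C1=O` gives 6240 nM, compound 2 `CN1CCc2nc(C#Cc3cccnc3)ccc2C1=O` gives 27400 nM, and compound 3 `CC(C)N1CCc2nc(C#Cc3ccccn3)ccc2C1=O` gives 2740 nM, the lowest of the three. Compound 4 `CC(C)N1CCc2nc(C#Cc3cccnc3)ccc2C1=O` has not yet been measured.

Compound 2 is made from compound 1 by one change, (pyridin-3-yl in place of pyridin-2-yl on a triple-bonded carbon), and this gave a 4.4-fold higher number from compound 1 to compound 2 (0.64 log units; beyond the scatter). The core of compound 3 differs from the core of compound 1 by another change, (isopropyl in place of methyl on an amide-type nitrogen in a ring), which gave a 2.3-fold lower number from compound 1 to compound 3 (0.36 log units; beyond the scatter).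

Compound 4 is made from compound 3 by the same change that turned compound 1 into compound 2: pyridin-3-yl in place of pyridin-2-yl on a triple-bonded carbon. The place where it happens is described in the same words in both pairs, so it is the same change, made here on the core of compound 3. Within the data shown here, the only guide to its effect is that earlier pair, and a swap seen once cannot show whether the core alters it. Resting on that single step, compound 4 is expected to show a 4.4-fold higher number from compound 3 to compound 4 (0.64 log units; beyond the scatter), close to the earlier one. The estimated result for compound 4 in this assay is 12000 nM, likely between 5500 nM and 30000 nM.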

Compound 4, inhibition constant: 19600 nM
Compound 4: the middle estimate sits 1.6-fold (0.21 log units) below what was measured; the range from low to high includes it.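

Moved onto the core of compound 3 in this assay, the swap of pyridin-2-yl for pyridin-3-yl gave a 7.2-fold higher number from compound 3 to compound 4 (0.85 log units; beyond the scatter) and so raised the number again, by an amount that matches the first time it was seen: the same change on two cores in this assay, a 4.4-fold higher number (0.64 log units; beyond the scatter) from compound 1 to compound 2 and a 7.2-fold higher number (0.85 log units; beyond the scatter) from compound 3 to compound 4, 1.6-fold (0.21 log units) apart, within the scatter of two such steps.
The other change, isopropyl in place of methyl on the amide-type nitrogen, gave a 1.4-fold lower number from compound 2 to compound 4 (0.15 log units; within the scatter) on the pyridin-3-yl compounds, so no real drop can be claimed there, yet this step cannot be told apart from its earlier counterpart either: the same change on two cores in this assay, a 2.3-fold lower number (0.36 log units; beyond the scatter) from compound 1 to compound 3 and a 1.4-fold lower number (0.15 log units; within the scatter) from compound 2 to compound 4, 1.6-fold (0.21 log units) apart, within the scatter of two such steps.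
Each change therefore behaved alike on the two cores within the limits of the measurements, but two cores form a very small sample and do not show that either step would carry over to any other core.

From the compounds shown here alone, it remains open whether a phenyl or pyridin-4-yl group on the triple-bonded carbon would follow the same trend. The same question stands for an ethyl group or a longer chain on the amide-type nitrogen.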